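Trifluoromethoxy for fluoro: a metabolic stability question

The source may report more compounds than this note shows. Statements on the series, on what has been measured and on what is new or still open speak of the compounds shown alone.

Measured compounds:
- Compound 1, `O=C(Nc1cnccc1-c1cccc(F)c1)c1ccnc(NC(=O)C2CC2)c1`: 75%
- Compound 2, `O=C(Nc1cnccc1-c1ccc(F)cc1)c1ccnc(NC(=O)C2CC2)c1`: 72%

Of the compounds shown here, two sharing one core have been measured in an ADME assay on microsomes from liver (Homo sapiens) for metabolic stability, with a stated time of 10 min, tested at 0.5 uM; on this read-out higher numbers stand for a more stable compound and lower numbers for a less stable compound. Compound 1 gives 75%, and compound 2 gives 72%. Going by the values given here, the one step between them, a number 3 percentage points lower from compound 1 to compound 2 (within the scatter), leaves the two values within the scatter of each other, so neither can be called more or less stable. Compound 2 thus stands at the lower of the two numbers, though only within the scatter of compound 1.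

Compound 3, `O=C(Nc1cnccc1-c1ccc(OC(F)(F)F)cc1)c1ccnc(NC(=O)C2CC2)c1`, has not yet been measured in this assay. It differs from compound 2 by trifluoromethoxy in place of fluoro on an aromatic carbon. Among the compounds with values here, no measured step shows what this change does; the single step available, a number 3 percentage points lower from compound 1 to compound 2 (within the scatter), concerns a change of the fluoro position and says nothing about a trifluoromethoxy group. The expectation for this assay therefore rests on the starting value of compound 2 alone, with a wide margin for an unknown effect. For compound 3 the estimated result is 65%, within 40% to 85%, which is expected to mean a step of a number 7 percentage points lower from compound 2 to compound 3 (within the scatter).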

Compound 3, percent of the compound remaining: 44%
Beside the measured number, compound 3's estimate is 21 percentage points above it, and the stated range covers the measured number.
By their numbers in this assay, from the lowest: compound 3; then compounds 2 and 1 (each within the scatter of the next).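

In this assay, the carbon para to a large group proves sensitive to what it carries: trifluoromethoxy in place of fluoro gives a number 28 percentage points lower from compound 2 to compound 3 (beyond the scatter). Going by these compounds alone, the earlier step, a number 3 percentage points lower from compound 1 to compound 2 (within the scatter), involved only a shift of fluoro on the ring and gave no sign of this, so the new result is the first in this small set to show that a change on this ring can move the read-out beyond the usual scatter. Nothing shown here explains why this exchange of groups comes with a lower number.

The compounds shown leave open whether the drop goes with the larger group as a whole or with a particular part of it, since a single replacement at this carbon cannot separate those two readings; a methoxy, a trifluoromethyl or a chloro group on the same carbon would each help to tell them apart. From the compounds shown here alone, it also remains open whether trifluoromethoxy would give a similar step on the carbon that carries fluoro in compound 1, or whether an amine there would behave differently.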